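The source may report more compounds than this note shows. Statements on the series, on what has been measured and on what is new or still open speak of the compounds shown alone.

Measured so far:
Compound 1, `O=C(O)c1ccc(-c2cccc(COc3ccc4c(c3)CN(C3CCCC3)C4=O)c2)c(Cl)c1`: 3%
Compound 2, `O=C(O)c1cc(-c2cccc(COc3ccc4c(=O)n(C5CC5)sc4c3)c2)ccc1Cl`: 86%
Compound 3, `O=C1c2ccc(OCc3cccc(-c4ccc(C(F)(F)F)cc4F)c3)cc2CN1C1CCCC1`: "not determined" (no result reported)

The question is how much of each compound survives an hour with liver microsomes, measured in an ADME assay on microsomes from liver (Rattus norvegicus) for metabolic stability, read by LC-MS, with a stated time of 1 h, at 37 degrees C, tested at 4 uM; a lower number here means that less of the compound is left, a higher number that more of the compound is left. Compound 1 gives 3%, whereas compound 2, built on a different core, gives 86%. For compound 3 no number was obtained in this assay, so it stands nowhere on the scale. Compound 4 `Cc1ccc(C(=O)O)cc1-c1cccc(COc2ccc3c(c2)CN(C2CCCC2)C3=O)c1` is the partner of compound 3 in the step: 5-carboxy-2-methylphenyl in place of 2-fluoro-4-(trifluoromethyl)phenyl on an aromatic carbon. With compound 3 unmeasured, the size and direction of this step cannot be judged. Compound 4 shares its core with compound 1, and its result is expected to be low for that reason. Compound 4 is expected to give 10%, within 2% to 35%, because compound 1 gives 3%.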

Compound 4, percent of the compound remaining: 2%
Beside the measured number, compound 4's estimate is 8 percentage points above it; the measured number falls inside the stated range.
By their numbers in this assay, from the lowest: compounds 4 and 1 (each within the scatter of the next); then compound 2.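

In this assay the swap of 4-carboxy-2-chlorophenyl for 5-carboxy-2-methylphenyl gives a number 1 percentage points lower from compound 1 to compound 4 (within the scatter) and so leaves the two compounds indistinguishable. On this position of the shared core, these two carboxy-bearing rings therefore read alike. The step from compound 3 to compound 4 cannot be read, as compound 3 has no number. Going by these compounds, whether an amine or a nitrile in place of the carboxylic acid on this ring would read differently remains open. Nothing measured here explains the result.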